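Moving the furan attachment in a propyl ester

The source may report more compounds than this note shows. Statements on the series, on what has been measured and on what is new or still open speak of the compounds shown alone.

In an assay on membranes from CHO cells for displacement of a labelled ligand from adenosine receptor A1 (Homo sapiens), read by scintillation counting, with a stated time of 60 min, tested at 1 uM (a lower number here means less inhibition, a higher number more inhibition at the concentration tested (going by the name of the read-out)), compound 1 `COC(=O)C1=C(C)N(C)C(=O)NC1c1ccco1` gives 45%, compound 3 `CC1=C(C(=O)OC(C)(C)C)C(c2ccco2)NC(=O)N1C` gives 44%, and compound 2 `CCCOC(=O)C1=C(C)N(C)C(=O)NC1c1ccco1` gives 3%, the lowest of the three. All measured steps change the ester only: a number 42 percentage points lower from compound 1 to compound 2 (beyond the scatter), a number 41 percentage points higher from compound 2 to compound 3 (beyond the scatter) and a number 1 percentage points lower from compound 1 to compound 3 (within the scatter). Compound 4 `CCCOC(=O)C1=C(C)N(C)C(=O)NC1c1ccoc1` differs from compound 2 in a different place: furan-3-yl in place of furan-2-yl on a saturated ring carbon. Within the data shown here, no measured step touches the furan-2-yl group, so nothing here shows how such a change acts, and the expectation rests on compound 2 alone, whose 3% is the starting point. Compound 4 is therefore expected to stay close to compound 2, with a number 7 percentage points higher from compound 2 to compound 4 (within the scatter) as the expected step, nothing beyond the scatter. The estimate for compound 4 is 10%, within -5% to 35%.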

Compound 4, a percentage reported as inhibition, at one concentration (the size of the read-out at that concentration, not a potency): 1%
Estimate against measurement, compound 4: 9 percentage points above, and the stated range covers the measured number.
By their numbers in this assay, from the lowest: compounds 4 and 2 (each within the scatter of the next); then compounds 3 and 1 (each within the scatter of the next).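

In this assay, the furan swap on the saturated ring carbon gives a number 2 percentage points lower from compound 2 to compound 4 (within the scatter) and is the first change shown at this position, with no shift beyond the scatter. Among these compounds, this holds only for the propyl ester, where compound 2 already has the lowest number of the earlier compounds, leaving little room for a further drop to show. Nothing available explains this result.

Going by these compounds, whether furan-3-yl would behave the same way with the methyl or tert-butyl ester remains open. So does the effect of a phenyl or thiophene ring on this carbon.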